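A few compounds are considered here, and "the series" means these few. Any claim that something is new, unique, unknown or untested is made for them only; others in the source may bear on it.

Measured compounds in a physicochemical assay for solubility, with a stated time of 18 h, at pH 7.4; on this read-out higher numbers stand for higher solubility and lower numbers for lower solubility:
- compound 1 `COc1ccc(F)cc1CNCCCNc1ccnc2cc(Cc3ccc(C#N)cc3)ccc12`: 4200 nM
- compound 2 `COc1ccc(F)cc1CNCCCNc1ccnc2cc(Cc3ccc(F)cc3Cl)ccc12`: 4200 nM
- compound 3 `COc1ccc(F)cc1CNCCCNc1ccnc2cc(Oc3cccc(N(C)C)c3)ccc12`: 14500 nM

Compound 3 stands highest of the three in this assay; its steps to compound 1 and to compound 2 are both beyond the scatter, and compound 1 and compound 2 sit within the scatter of each other, as no change at the digits printed from compound 1 to compound 2 (within the scatter) shows.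

Compound 4 `COc1ccc(-c2ccc3c(NCCCNCc4cc(F)ccc4OC)ccnc3c2)cc1` differs from compound 3 in one place: 4-methoxyphenyl in place of 3-(dimethylamino)phenoxy on an aromatic carbon. Going by the values given here, the steps that bear on this are a 3.5-fold higher number from compound 1 to compound 3 (0.54 log units; beyond the scatter) and a 3.5-fold higher number from compound 2 to compound 3 (0.54 log units; beyond the scatter), where the 3-(dimethylamino)phenoxy group entered in place of a benzyl group. In compound 4 that same group leaves, so the expectation is a step back toward the level shared by compound 1 and compound 2. Among the compounds with values here, no measured step covers an aryl group bound directly to the core, so the size is uncertain. A modest lower number is expected, a 3.6-fold lower number from compound 3 to compound 4 (0.56 log units; beyond the scatter). The estimate for compound 4 in this assay is 4000 nM, with a range from 1500 nM to 10000 nM.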

Compound 4, solubility: 32000 nM
For compound 4 the middle estimate is 8.0-fold (0.90 log units) below the measured one; the whole stated range lies below it.
By their numbers in this assay, from the lowest: compounds 1 and 2 (each within the scatter of the next); then compound 3; then compound 4.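

In this assay, the 4-methoxyphenyl group on this aromatic carbon of the shared core gives a 2.2-fold higher number from compound 3 to compound 4 (0.34 log units; beyond the scatter), so removing 3-(dimethylamino)phenoxy here does not return the number to the level of the benzyl compounds. The changes from the benzyl groups are larger, at a 7.6-fold higher number from compound 2 to compound 4 (0.88 log units; beyond the scatter) and a 7.6-fold higher number from compound 1 to compound 4 (0.88 log units; beyond the scatter), and show that a nitrogen in the group at this position is not required for the highest number among these four compounds. Nothing measured here accounts for this order.

Open, from the compounds shown here alone, is whether the direct aryl link to the core or the methoxy group carries the step, a question that a plain phenyl or a 4-methoxybenzyl group at this position would settle. Also open, going by these compounds, is whether a morpholine or a carboxylic acid on the aryl ring would hold the number at this level.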